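A few compounds are considered here, and "the series" means these few. Any claim that something is new, unique, unknown or untested is made for them only; others in the source may bear on it.

Compound 3 `C=CC(=O)NCc1coc(-c2c(N)ncnc2Nc2ccc(Oc3ccc(F)cc3)c(Cl)c2)n1` is the point of departure. In an in vitro ADME assay on microsomes from liver (Mus musculus) for metabolic stability, tested at 5 uM (on this read-out higher numbers stand for a longer-lived compound and lower numbers for a shorter-lived compound), compound 3 gives > 1.66 h, which is a limit of the assay rather than a number. Among the other measured members of the series, compound 1 `C=CC(=O)NCc1coc(-c2c(N)ncnc2Nc2ccc(OCc3ccccn3)c(F)c2)n1` gives 0.15 h and compound 2 `C=CC(=O)NCc1coc(-c2c(N)ncnc2Nc2ccc(Oc3ccccc3)c(Cl)c2)n1` gives 0.8 h in this assay. Among the compounds with values here, the only step measured across a single change is an at least 2.0-fold higher number from compound 2 to compound 3 (0.31 log units; beyond the scatter), fluoro in place of hydrogen on an aromatic carbon. Going by these compounds, its upper end stays open, since compound 3 sits at the limit (the limit of > 1.66 h in this assay, at which 1 of the 3 values shown sits).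

Compound 4 `C=CC(=O)NCc1coc(-c2c(N)ncnc2Nc2ccc(F)c(Cl)c2)n1` differs from compound 3 in another way: fluoro in place of 4-fluorophenoxy on an aromatic carbon. Within the data shown here, no measured step bears on this change; the one step known concerns a substituent on the phenoxy group, not its removal, so neither direction nor size is set by the data. The half-life of compound 4 in this assay is therefore estimated at 1 h, within 0.3 h to 3 h. The step of an at least 1.6-fold lower number from compound 3 to compound 4 (0.22 log units; that floor lies within the scatter) that this estimate means is expected to lie near no change, with a wide range around it.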

Compound 4, half-life: 0.15 h
Compound 4: the middle estimate sits 6.7-fold (0.82 log units) above what was measured; the measured number lies below the stated range.
By their numbers in this assay, from the lowest: compounds 1 and 4 (each within the scatter of the next); then compound 2. At a limit, above all of these: compound 3.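

Fluoro in place of 4-fluorophenoxy on this aromatic carbon, ortho to a chloro group, gives an at least 11-fold lower number from compound 3 to compound 4 (1.04 log units; beyond the scatter) in this assay, and fluoro in place of phenoxy gives a 5.3-fold lower number from compound 2 to compound 4 (0.73 log units; beyond the scatter). Both steps point the same way, so for these compounds the half-life depends on the group held at this position itself, whereas the earlier step showed only the effect of a fluoro on the phenoxy ring. The first of these steps rests on a limit of the assay, which leaves its upper end open: the limit of > 1.66 h in this assay, at which 1 of the 4 values shown sits.

Going by these compounds, whether the whole aromatic ring is needed stays open; methoxy or cyclohexyloxy at this position would separate the ether oxygen from that ring. Also open, on these data alone, is whether a group such as an amine or a longer alkoxy chain would hold the half-life here.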